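Nitro in place of chloro on the shared core

The source may report more compounds than this note shows. Statements on the series, on what has been measured and on what is new or still open speak of the compounds shown alone.

In a functional assay on NCI-H460 cells (Homo sapiens) for cytotoxicity, read by MTT assay, with a stated time of 72 h (on this read-out lower numbers stand for stronger inhibition of growth and higher numbers for weaker inhibition of growth), compound 2 `Cc1ccc(/C=C(/C#N)C(=O)c2ccc[nH]2)cc1` gives 11000 nM and compound 3 `N#C/C(=C/c1ccc(Cl)cc1)C(=O)c1ccc[nH]1` gives 38000 nM as the higher of the two numbers. Compound 1 `N#C/C(=C/c1ccc2ccccc2c1)C(=O)c1ccc[nH]1` gives < 10000 nM as a limit and not a number. Compound 4 `N#C/C(=C/c1ccc([N+](=O)[O-])cc1)C(=O)c1ccc[nH]1` has nitro in place of chloro on an aromatic carbon, para to a large group, counted as nitro in place of chloro on an aromatic carbon in the change. Going by the values given here, the one measured step at this place is chloro in place of methyl, with a 3.5-fold higher number from compound 2 to compound 3 (0.54 log units; beyond the scatter) as a modest move beyond the scatter. On these data alone, it involves no nitro, so no step beyond the scatter is expected and the direction stays open. The expected change is a 1.5-fold lower number from compound 3 to compound 4 (0.18 log units; within the scatter) on this estimate. Compound 4 is estimated at 25000 nM with an expected range from 8000 nM to 75000 nM as a working figure.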

Compound 4, concentration for 50% growth inhibition: < 10000 nM
Compound 4 was reported as a limit; the forecaster's own chance of this, stated with the estimate: 15%; at least 2.5-fold (0.39 log units) between middle value and limit.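

Chloro in place of methyl raised the number, with a 3.5-fold higher number from compound 2 to compound 3 (0.54 log units; beyond the scatter), but this position also allows a move the other way: nitro in place of chloro gives an at least 3.8-fold lower number from compound 3 to compound 4 (0.57 log units; beyond the scatter). Against methyl, the nitro compound gives an at least 1.1-fold lower number from compound 2 to compound 4 (0.04 log units; that floor lies within the scatter), so compound 4 is not separated from compound 2. The value of compound 4 is a limit, and the full size of both new steps remains unread: the limit of < 10000 nM in this assay, at which 2 of the 4 values shown sit.

Open, on these data alone, is how an amine or a carboxylic acid on this aromatic carbon would read. Also open, as far as these compounds go, is whether compound 4 and compound 1 differ.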